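Swapping a Methyl for a Formyl on the Outer Ring

This account rests on a few compounds, and the source may have more. Where it says the series, first, only, none or still open, it means among the compounds named here.

Of the compounds shown here, three sharing one core have been tested in a functional assay on HCT-116 cells (Homo sapiens) for antiproliferative activity, read by MTT assay, with a stated time of 48 h; a lower number here means a stronger inhibitor, a higher number a weaker inhibitor. Compound 3 `COc1cc(/C=C/C(C)=O)ccc1OCc1cn(-c2ccc(C)cc2)nn1` gives 76600 nM, the higher of the two numbers obtained. Compound 2 `COc1cc(/C=C/C(C)=O)ccc1OCc1cn(-c2c(Cl)cccc2Cl)nn1` gives 2000 nM. Compound 1 `COc1cc(/C=C/C(C)=O)ccc1OCc1cn(-c2ccc(/N=N/c3ccccc3)cc2)nn1` reaches only the limit of the measurement, > 100000 nM. The step of a 38-fold higher number from compound 2 to compound 3 (1.58 log units; beyond the scatter) is large, whereas the step of an at least 1.3-fold lower number from compound 1 to compound 3 (0.11 log units; that floor lies within the scatter) cannot be resolved. Compound 4 `COc1cc(/C=C/C(C)=O)ccc1OCc1cn(-c2ccc(C=O)cc2)nn1` differs from compound 3 in one group: formyl in place of methyl on an aromatic carbon. Because the step of an at least 1.3-fold lower number from compound 1 to compound 3 (0.11 log units; that floor lies within the scatter) stayed within the scatter, compound 4 is expected to show a step of a 1.5-fold lower number from compound 3 to compound 4 (0.19 log units; within the scatter), staying weak. Compound 4 is estimated at 50000 nM, within a range from 10000 nM to 200000 nM.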

Compound 4, half-maximal inhibitory concentration: 76200 nM
Compound 4: the middle estimate sits 1.5-fold (0.18 log units) below what was measured; the measured number falls inside the stated range.
By their numbers in this assay, from the lowest: compound 2; then compounds 4 and 3 (each within the scatter of the next). At a limit, above all of these: compound 1.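

In this assay, a formyl group para to a large group, which brings a hydrogen-bond acceptor that methyl lacks, gives a step that lies within the scatter: a 1.0-fold lower number from compound 3 to compound 4 (0.00 log units; within the scatter). The large gap to the 2,6-dichlorophenyl compound therefore holds for 4-formylphenyl as it did for 4-methylphenyl: a 38-fold higher number from compound 2 to compound 4 (1.58 log units; beyond the scatter). The remaining step gives only a floor and cannot be read: an at least 1.3-fold lower number from compound 1 to compound 4 (0.11 log units; that floor lies within the scatter). Compound 1 gives only a limit: the limit of > 100000 nM in this assay, at which 1 of the 4 values shown sits.

The compounds shown leave open whether an amine or a carboxylic acid in this place would move the number. They also leave open whether a single chlorine on the outer ring would be enough to reach the number of compound 2.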